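This account rests on a few compounds, and the source may have more. Where it says the series, first, only, none or still open, it means among the compounds named here.

In a functional assay on HepG2 cells (Homo sapiens) for inhibition, read by sulforhodamine B assay, with a stated time of 74 h (a lower number here means a stronger inhibitor, a higher number a weaker inhibitor), compound 1 `Cc1ccc(S(=O)(=O)N2C(=O)COC23C=CC(=O)C=C3)cc1` gives > 10000 nM, which is a limit of the assay and not a number. Compound 2 `N#Cc1cccc(S(=O)(=O)N2C(=O)COC23C=CC(=O)C=C3)c1` shares the core of compound 1. Compound 2 gives > 10000 nM, and this too is a limit. The record for the two compounds is therefore (the limit of > 10000 nM in this assay, at which 2 of the 2 values shown sit), and neither has a measured potency to compare.

Compound 3 `O=C1C=CC2(C=C1)OCC(=O)N2S(=O)(=O)c1ccc(C(F)(F)F)cc1` follows from compound 1 with trifluoromethyl in place of methyl on an aromatic carbon, para to a large group: trifluoromethyl in place of methyl on an aromatic carbon. Going by the values given here, no measured step shows what such a change does here. With compound 1 and compound 2 both at the limit of > 10000 nM in this assay, at which 2 of the 2 values shown sit, no step beyond the scatter is expected in this assay. The expected change is a step that the limit leaves unreadable from compound 1 to compound 3. Compound 3 is estimated at 15000 nM, with an expected range from 6000 nM to 40000 nM.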

Compound 3, half-maximal inhibitory concentration: 750 nM
For compound 3 the middle estimate is 20-fold (1.30 log units) above the measured one, and the stated range ends above it.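

Trifluoromethyl in place of methyl on an aromatic carbon, para to a large group, brings an at least 13-fold lower number from compound 1 to compound 3 (1.12 log units; beyond the scatter) in this assay. Going by these compounds alone, this position therefore responds to what stands on it, which the earlier compounds could not show. Compound 3 is the only compound shown with a measured potency, so the core of compound 1 can carry activity in this read-out, while the others give no number to compare: the limit of > 10000 nM in this assay, at which 2 of the 3 values shown sit.

From the compounds shown here alone, the step starts from a limit, and its full size stays open. Going by these compounds, whether a chlorine atom, a methoxy group or an amine on this same carbon would also give a measurable potency remains open, as does whether a second trifluoromethyl elsewhere on the ring would add to it.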